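A few compounds are considered here, and "the series" means these few. Any claim that something is new, unique, unknown or untested is made for them only; others in the source may bear on it.

Compound 1 `Nc1ccn([C@@H]2C=C(F)[C@H](CO)O2)c(=O)n1` and compound 2 `O=c1nc(O)ccn1[C@@H]1C=C(F)[C@H](CO)O1` share one core, while compound 3 `Nc1ncnc2c1ncn2[C@@H]1CC(F)(F)[C@H](CO)O1` and the still unmeasured compound 4 `OC[C@@H]1O[C@H](n2cnc3c(O)ncnc32)CC1(F)F` share another; the difference between the two cores is not broken down here. The three measured compounds were tested in a functional assay on Vero cells (Chlorocebus sabaeus) for cytotoxicity; on this read-out higher numbers stand for weaker inhibition and lower numbers for stronger inhibition. In this assay compound 1 reaches only the limit of the assay, > 100000 nM, which is a limit and not a number. For compound 2 this assay likewise stops at its limit, > 100000 nM. Compound 3 also gives only a limit in this assay, > 100000 nM.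

The change from compound 1 to compound 2 is hydroxy in place of amino on an aromatic carbon. Its step, a step that the two limits leave unreadable from compound 1 to compound 2, cannot be sized, since both ends of it are limits. The same kind of change is made from compound 3 to compound 4, (hydroxy in place of amino on an aromatic carbon). The surroundings differ: in compound 4 the carbon carrying the group belongs to a six-membered aromatic ring with 2 nitrogen that is part of a fused or bridged system of two rings, ortho to a fused ring and meta to a fused ring, whereas in compound 2 the ring stands alone and the place is meta to a group of 1 heavy atom and para to a group of 8 heavy atoms.

Because every measured value sits at the limit of > 100000 nM in this assay, at which 3 of the 3 values shown sit, the step from compound 3 to compound 4 is expected to be a number no higher from compound 3 to compound 4 (the limit leaves the size open), beside the earlier step that could not be read. Compound 4 is estimated to give 100000 nM, with an expected range from 50000 nM to 200000 nM, and most likely the assay will again report only a limit.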

Compound 4, half-maximal inhibitory concentration: > 100000 nM
Compound 4: no number, only a limit (the forecaster's own chance of this, stated with the estimate: 85%); the middle value sits exactly at the limit.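

Compound 4 gives only a limit in this assay, as compound 3 does, so no step can be read from compound 3 to compound 4, and the swap of amino for hydroxy stays without a size. The compounds shown leave open whether this swap, or the difference between the two cores, changes the read-out at all, with every value resting on one limit: the limit of > 100000 nM in this assay, at which 4 of the 4 values shown sit.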